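Biaryl nitro-alcohol series: cytotoxicity on changing the distal ring

This account rests on a few compounds, and the source may have more. Where it says the series, first, only, none or still open, it means among the compounds named here.

Measured so far in an ADME assay on HeLa Rh cells (Homo sapiens) for cytotoxicity, read by microscopy; on this read-out higher numbers stand for lower toxicity in this test and lower numbers for higher toxicity in this test:
compound 1 `COc1cc(CC(O)c2ccc(-c3ccc(C=O)cc3)cc2)c([N+](=O)[O-])cc1OC` gives > 245000 nM, a limit of the assay and not a number.
compound 2 `COc1cc(CC(O)c2ccc(-c3ccc(Cl)cc3)cc2)c([N+](=O)[O-])cc1OC` gives 4100 nM.

Compound 2 carries the only number shown; the other value is the limit of > 245000 nM in this assay, at which 1 of the 2 values shown sits. Within the data shown here, the one measured step, an at least 59-fold lower number from compound 1 to compound 2 (1.77 log units; beyond the scatter), is large. Compound 3 `COc1cc(CC(O)c2ccc(-c3ccccc3C#N)cc2)c([N+](=O)[O-])cc1OC` differs from compound 2 by 2-cyanophenyl in place of 4-chlorophenyl on an aromatic carbon. That step bears on it only loosely, since both compound 1 and compound 3 lack the chlorine; a sizeable rise in this assay is expected, with wide uncertainty. For compound 3 the estimate is 60000 nM, ranging from 10000 nM to 245000 nM. This expectation amounts to a 15-fold higher number from compound 2 to compound 3 (1.17 log units; beyond the scatter).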

Compound 3, half-maximal cytotoxic concentration: 9300 nM
The estimate for compound 3 lay 6.5-fold (0.81 log units) above the measured number; measured number below the stated range.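

Low numbers in this assay are not tied to the chlorine: with 2-cyanophenyl in its place, the step is only a 2.3-fold higher number from compound 2 to compound 3 (0.36 log units; beyond the scatter). Among the three compounds, only the 4-formylphenyl compound stands well apart, with an at least 26-fold lower number from compound 1 to compound 3 (1.42 log units; beyond the scatter). That step gives a minimum size and not a measured gap: the limit of > 245000 nM in this assay, at which 1 of the 3 values shown sits.

On these data alone, a carboxylic acid or an amine on this ring remains open, as does how far it would carry the number toward that of compound 1. The step from compound 2 changes both the group and its place on the ring, so the two cannot be separated.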